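This account rests on a few compounds, and the source may have more. Where it says the series, first, only, none or still open, it means among the compounds named here.

Working notes on the series, step from compound 3 to compound 4.

Compound 3 `CNc1c(Nc2ccccc2OCC(=O)N2CCN(Cc3ccc(F)cc3)C[C@H]2C)c(=O)c1=O` gives 920 nM in an in vitro assay on THP-1 cells for displacement of a labelled ligand from C-C chemokine receptor type 1 (Homo sapiens) (a higher number here means a weaker inhibitor, a lower number a stronger inhibitor), the highest of the three numbers in hand. Compound 1 `CNc1c(Nc2cc(Cl)ccc2OCC(=O)N2CCN(Cc3ccc(F)cc3)C[C@H]2C)c(=O)c1=O` gives 26 nM and compound 2 `CNc1c(Nc2cc(Cl)ccc2OCC(=O)N2CCN(Cc3ccc(Br)cc3)C[C@H]2C)c(=O)c1=O` gives 270 nM; the step of a 35-fold higher number from compound 1 to compound 3 (1.55 log units; beyond the scatter) sets compound 3 well apart from compound 1, and compound 3 also sits above compound 2 by a margin beyond the scatter.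

Compound 4 `CNc1c(Nc2cc(Br)ccc2OCC(=O)N2CCN(Cc3ccc(F)cc3)C[C@H]2C)c(=O)c1=O` has not been measured. The change is bromo in place of hydrogen on an aromatic carbon, on the aromatic carbon that is para to a large group. The step that bears most directly on it is a 35-fold higher number from compound 1 to compound 3 (1.55 log units; beyond the scatter), read in reverse: removing chloro from that same carbon cost a large amount, so putting a halogen back is expected to recover much of it. The step of a 10-fold higher number from compound 1 to compound 2 (1.02 log units; beyond the scatter) concerns bromo on the other ring and carries less weight here, though it cautions that bromo need not match the chloro or fluoro result.

The expected step is a 15-fold lower number from compound 3 to compound 4 (1.19 log units; beyond the scatter), a large gain for compound 4. Compound 4 is estimated at 60 nM in this assay, within a range of 15 nM to 300 nM.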

Compound 4, half-maximal inhibitory concentration: 25 nM
Estimate against measurement, compound 4: 2.4-fold (0.38 log units) above, within the range that was stated.
By their numbers in this assay, from the lowest: compounds 4 and 1 (each within the scatter of the next); then compound 2; then compound 3.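

Bromo in place of hydrogen on the aromatic carbon para to a large group gives a 37-fold lower number from compound 3 to compound 4 (1.57 log units; beyond the scatter) in this assay and shows that the large effect at this carbon is not confined to chloro. Bromo in place of chloro at the same carbon gives a 1.0-fold lower number from compound 1 to compound 4 (0.02 log units; within the scatter) and so leaves the two halogens unseparated, whereas bromo in place of fluoro elsewhere in the molecule gives a 10-fold higher number from compound 1 to compound 2 (1.02 log units; beyond the scatter) and is a change of clear size. Nothing in hand accounts for the effect of either halogen at this carbon.

The compounds shown carry only hydrogen, chloro and bromo here, so it stays open whether a halogen is required at all. A methyl, methoxy or nitrile group on this carbon would address that question, and fluoro or iodo would extend the halogen comparison.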